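This account rests on a few compounds, and the source may have more. Where it says the series, first, only, none or still open, it means among the compounds named here.

Compound 2 `COc1cc(-c2nn(-c3cccc(NC(=O)Nc4ccc(Cl)c(Cl)c4)c3)cc2-c2ccncc2)ccc1Cl` gives 1040 nM in a functional assay on CCRF-CEM cells (Homo sapiens) for inhibition, read by sulforhodamine B assay, with a stated time of 48 h (a lower number here means a stronger inhibitor of growth, a higher number a weaker inhibitor of growth), the highest of the three numbers measured. Compound 3 `O=C(Nc1cccc(-n2cc(-c3ccncc3)c(-c3ccc(Cl)c(O)c3)n2)c1)Nc1ccc(Cl)c(Cl)c1` gives 1030 nM, and the change a 1.0-fold lower number from compound 2 to compound 3 (0.00 log units; within the scatter) lies within the scatter. Compound 1 `COc1cc(-c2nn(-c3cccc(NC(=O)Nc4cc(C(F)(F)F)cc(C(F)(F)F)c4)c3)cc2-c2ccncc2)ccc1Cl`, which carries two trifluoromethyl groups on the urea-bearing ring, gives 498 nM, beyond the scatter from compound 2. Compound 4 `COc1cc(-c2nn(-c3cccc(NC(=O)Nc4ccc(Cl)c(C(F)(F)F)c4)c3)cc2-c2ccncc2)ccc1Cl` differs from compound 2 by trifluoromethyl in place of chloro on an aromatic carbon. Among the measured compounds shown here, no measured step tracks this exact change; the values of compound 1 and compound 2 merely suggest that trifluoromethyl groups on this ring go with a somewhat lower number. Compound 4 is therefore expected to move by a 1.4-fold lower number from compound 2 to compound 4 (0.16 log units; within the scatter), giving an estimated 720 nM with a range from 360 nM to 1450 nM.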

Compound 4, concentration for 50% growth inhibition: 980 nM
Beside the measured number, compound 4's estimate is 1.4-fold (0.13 log units) below it; measured number inside the range.
By their numbers in this assay, from the lowest: compounds 1, 4, 3 and 2 (each within the scatter of the next, the first and the last beyond it).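

Trifluoromethyl in place of chloro, ortho to a chloro group, gives no readable change in this assay: the step is a 1.1-fold lower number from compound 2 to compound 4 (0.03 log units; within the scatter). This position therefore accepts a group of 4 heavy atoms where a single atom stood, with growth inhibition staying within the scatter. Nothing available explains why the swap makes so little difference. Still open, going by these compounds, is whether this position stays as undemanding with a group of a different kind, such as an amine or a carboxylic acid. On these data alone, whether the neighbouring chloro group matters to this result also remains unknown.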